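The source may hold more compounds than are shown below. What is called first, only, known or untested is meant among the compounds shown, and "the series" means these compounds.

Series notes. Compound 1 `Cc1cc(/C=C/C#N)cc(C)c1Oc1cc(NCCN(C)C)nc(Nc2ccc(C#N)cc2)c1` is the reference point. In an ADME assay on MT4 cells (Homo sapiens) for cytotoxicity, read by MTT assay, with a stated time of 5 days (a lower number here means that less compound is tolerated, a higher number that more compound is tolerated), compound 1 gives 4270 nM, the highest of the three numbers recorded so far. Compound 2 `COC(Nc1cc(Oc2c(C)cc(/C=C/C#N)cc2C)nc(Nc2ccc(C#N)cc2)n1)OC` gives 3470 nM, which lies within the scatter of compound 1. Compound 3 `Cc1cc(/C=C/C#N)cc(C)c1Oc1cc(NCCC#N)nc(Nc2ccc(C#N)cc2)n1` gives 1000 nM, separated from compound 1 by more than the scatter. For the measured compounds named here, the only step measured between close neighbours, a 3.5-fold lower number from compound 2 to compound 3 (0.54 log units; beyond the scatter), concerns the substituent on a nitrogen on an aromatic ring. Compound 4 `Cc1cc(/C=C/C#N)cc(C)c1Oc1cc(Cl)nc(Nc2ccc(C#N)cc2)c1` departs from compound 1 in a different way: chloro in place of (2-(dimethylamino)ethyl)amino on an aromatic carbon. Going by the values given here, no measured step exchanges such a nitrogen-linked chain for chloro, so the step from compound 2 to compound 3 serves only as an indication of the scale that a change at this part of the core can reach. The step expected here, a 1.4-fold lower number from compound 1 to compound 4 (0.15 log units; within the scatter), is small and not clearly beyond the scatter, with wide uncertainty in either direction. Compound 4 is estimated at 3000 nM, within a range of 1000 nM to 9000 nM.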

Compound 4, half-maximal cytotoxic concentration: > 311000 nM
Compound 4 ended at the assay's limit; the forecaster's own chance of this, stated with the estimate: 10%; middle value at least 100-fold (2.01 log units) from the limit.
By their numbers in this assay, from the lowest: compound 3; then compounds 2 and 1 (each within the scatter of the next). At a limit, above all of these: compound 4.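

In this assay, chloro in place of (2-(dimethylamino)ethyl)amino on this aromatic carbon gives an at least 72-fold higher number from compound 1 to compound 4 (1.86 log units; beyond the scatter), so a single exchange at this position can move the read-out strongly. The earlier step, a 3.5-fold lower number from compound 2 to compound 3 (0.54 log units; beyond the scatter), exchanged one nitrogen-linked chain for another, whereas this change removes the nitrogen-linked chain altogether and reaches much further, in the opposite direction. For compound 4, > 311000 nM is a limit of the assay and not a number: the limit of > 311000 nM in this assay, at which 1 of the 4 values shown sits.

Which part of the departing group carries the step remains open, as does any separate contribution of chloro itself; a plain amine, a shorter chain ending in dimethylamino or a carboxylic acid on the same carbon would separate these. Going by these compounds, the full size of the step also remains open.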